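The source may hold more compounds than are shown below. What is called first, only, known or untested is meant among the compounds shown, and "the series" means these compounds.

Measured compounds:
compound 1 `CNc1nc(NCc2ccc(C(=O)NC3CCN(Cc4ccc(F)cc4)CC3)cc2)c2cc(C)ccc2n1` gives 1300 nM in a functional assay on SW480 cells (Homo sapiens) for inhibition, read by luminescence and resazurin assay, with a stated time of 3 days; a higher number here means a weaker inhibitor, a lower number a stronger inhibitor
compound 2 `CN1CCN(c2nc(NCc3ccc(NC(=O)c4ccc(F)cc4)cc3)c3ccccc3n2)CC1` gives 2500 nM in this assay
compound 3 `CNc1ncc(C)c(NCc2ccc(NC(=O)c3ccc(F)cc3)cc2)n1` gives > 20000 nM in this assay; this is a limit of the assay, not a number

Of these three values, two are numbers and one is a limit. Compound 1 and compound 2 lie within the usual scatter of each other in this assay, so the data do not separate them. For compound 3 only the limit of > 20000 nM in this assay, at which 1 of the 3 values shown sits, is known, and nothing more can be said about it.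

Compound 4 `CCCNc1nc(NCc2ccc(C(=O)NC3CCN(Cc4ccc(F)cc4)CC3)cc2)c2cc(C)ccc2n1` has not been measured. It differs from compound 1 in one place: ethyl in place of hydrogen on a saturated chain carbon bound to a nitrogen on an aromatic ring, that is, methylamino becomes propylamino on the shared core. Within the data shown here, no measured pair shows a change of this kind, so the expected size of the step rests only on the general picture. The expectation is that the step from compound 1 to compound 4 in this assay stays small, a 1.2-fold lower number from compound 1 to compound 4 (0.07 log units; within the scatter), with no clear direction beyond the scatter. Compound 4 is therefore expected to give about 1100 nM in this assay, within a range from 350 nM to 3500 nM.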

Compound 4, half-maximal inhibitory concentration: 1100 nM
Beside the measured number, compound 4's estimate shows no gap at the digits printed; low and high end bracket the measured number.
By their numbers in this assay, from the lowest: compounds 4, 1 and 2 (each within the scatter of the next, the first and the last beyond it). At a limit, above all of these: compound 3.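

Among these compounds, this is the first measured change at this position: methylamino becoming propylamino on the shared core, with ethyl in place of hydrogen on a saturated chain carbon bound to a nitrogen on an aromatic ring, gives a 1.2-fold lower number from compound 1 to compound 4 (0.07 log units; within the scatter) in this assay. For this one pair, then, the added ethyl leaves the number within the scatter, so the position accepts propylamino without a step that can be read in either direction. No measurement shown bears on why the step has this size.

Still open, as far as these compounds go, is how this position would respond to a much longer chain, such as octyl, or to a chain ending in a carboxylic acid or an amine. A single pair also cannot show whether the same change would read alike on a different core.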